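Trading the amino group of compound 1 for hydrogen

This account rests on a few compounds, and the source may have more. Where it says the series, first, only, none or still open, it means among the compounds named here.

Compound 1 `Nc1nc(Cl)c2ncn(Cc3ccccc3CCl)c2n1` gives the lowest of the two numbers measured in a functional assay on HCC 2998 cells (Homo sapiens) for cytotoxicity, read by sulforhodamine B assay, with a stated time of 48 h (on this read-out higher numbers stand for lower toxicity in this test and lower numbers for higher toxicity in this test), with 26300 nM. Compound 2 `ClCc1ccc(Cn2cnc3c(Cl)nc(Cl)nc32)cc1` gives 56200 nM in this assay, a higher number that lies beyond the usual scatter. Compound 3 `ClCc1ccccc1Cn1cnc2c(Cl)ncnc21` has not yet been measured; it differs from compound 1 in one place: hydrogen in place of amino on an aromatic carbon. Among the compounds with values here, no measured pair shows this change alone, so any expectation rests on compound 1 and compound 2. A small shift toward a higher number, or none beyond the scatter, is expected. Compound 3 is estimated at 35000 nM, within 12000 nM to 100000 nM, an expected step of a 1.3-fold higher number from compound 1 to compound 3 (0.12 log units; within the scatter).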

Compound 3, concentration lethal to 50% of the cells: 7410 nM
Beside the measured number, compound 3's estimate is 4.7-fold (0.67 log units) above it, outside the stated range (below it).
By their numbers in this assay, from the lowest: compound 3; then compound 1; then compound 2.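

In this assay, hydrogen in place of amino on the aromatic carbon between two ring nitrogen atoms gives a 3.5-fold lower number from compound 1 to compound 3 (0.55 log units; beyond the scatter) and so marks higher toxicity in this test. Within the data shown here, this is the first direct reading of this position, since compound 1 and compound 2 differ in more than one place, and it shows that the amino group is not required for this toxicity. Nothing available explains the shift.

As far as these compounds go, how a methylamino group or a methoxy group on this same carbon would compare with amino and hydrogen remains open.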